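The compounds below may be only part of what the source reports. "The series", "measured", "known", "first", "only" and "open" are said of these compounds alone.

Compound 1 `O=C(C1COc2ccccc2O1)N1N=C(c2ccc(Br)cc2)CC1c1ccccc1F` gives 8030 nM in a functional assay on WM 266-4 cells (Homo sapiens) for inhibition, read by MTT assay, with a stated time of 24 h; on this read-out higher numbers stand for weaker inhibition of growth and lower numbers for stronger inhibition of growth. Compound 2 `COc1ccc(C2=NN(C(=O)c3ccc4c(c3)OCCO4)C(c3ccccc3)C2)cc1` gives 2370 nM. Compound 3 `COc1ccc(C2=NN(C(=O)c3ccc4c(c3)OCCO4)C(c3ccc(OC)cc3)C2)cc1` gives 9890 nM.

Compound 2 holds the lowest number of the three, with compound 1 next and compound 3 furthest, both steps beyond the scatter. Compound 4 `O=C(c1ccc2c(c1)OCCO2)N1N=C(c2ccccc2)CC1c1ccccc1` differs from compound 2 by hydrogen in place of methoxy on an aromatic carbon. For the measured compounds named here, the one measured step that bears on this, a 4.2-fold higher number from compound 2 to compound 3 (0.62 log units; beyond the scatter), concerns a methoxy entering on the other aromatic ring of the same core, so it only loosely guides the change here, and no measured step shows what the methoxy of compound 2 itself contributes. The expected step from compound 2 to compound 4 is therefore modest and uncertain in direction, a 1.5-fold higher number from compound 2 to compound 4 (0.17 log units; within the scatter). Compound 4 is estimated at 3500 nM, within the range 1200 nM to 10000 nM.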

Compound 4, concentration for 50% growth inhibition: 1370 nM
Compound 4: middle estimate off by 2.6-fold (0.41 log units), on the high side; low and high end bracket the measured number.
By their numbers in this assay, from the lowest: compounds 4 and 2 (each within the scatter of the next); then compounds 1 and 3 (each within the scatter of the next).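

The 4-methoxyphenyl to phenyl change, on the ring para to a large group, gives a 1.7-fold lower number from compound 2 to compound 4 (0.24 log units; within the scatter), so at this position the methoxy and hydrogen cannot be told apart on this read-out. A methoxy entering on the other aromatic ring gave a 4.2-fold higher number from compound 2 to compound 3 (0.62 log units; beyond the scatter), so the two rings of this core do not respond alike to this group. Nothing available explains this result. Going by these compounds, whether an amine or a carboxylic acid at this position would move the number beyond the scatter stays open.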